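A few compounds are considered here, and "the series" means these few. Any claim that something is new, unique, unknown or untested is made for them only; others in the source may bear on it.

Working notes on the series in a functional assay on MCF7 cells (Homo sapiens) for antiproliferative activity, read by MTT assay, with a stated time of 6 days; a higher number here means a weaker inhibitor, a lower number a stronger inhibitor. Compound 1 `COc1ccc(/C=C/C(=O)OC[C@@H](OCc2ccccc2)[C@H]2OC(=O)C=C[C@H]2OCc2ccccc2)cc1` gives 1110 nM in this assay. Within the data shown here, compound 2 `O=C1C=C[C@@H](OCc2ccccc2)[C@@H]([C@@H](COC(=O)/C=C/c2ccc(F)cc2)OCc2ccccc2)O1` gives 3010 nM in this assay, the highest of the two numbers so far; the one step to it, a 2.7-fold higher number from compound 1 to compound 2 (0.43 log units; beyond the scatter), is the only measured change at this position of the aryl ring, and it moved the number upward. Compound 3 `O=C1C=C[C@@H](OCc2ccccc2)[C@@H]([C@@H](COC(=O)/C=C/c2ccc([N+](=O)[O-])cc2)OCc2ccccc2)O1` differs from compound 2 in one place: nitro in place of fluoro on an aromatic carbon. Among the measured compounds shown here, no measured step swaps fluoro for nitro, so the step from compound 1 to compound 2 bears on it only as a sign that this position of the ring tolerates a change of substituent with a modest shift. With a single step, and that in a different direction of substitution, no large movement is expected beyond the scatter in this assay; the estimated step of a 1.2-fold lower number from compound 2 to compound 3 (0.08 log units; within the scatter) is within the scatter. Compound 3 is therefore expected at about 2500 nM in this assay, within 900 nM to 7000 nM.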

Compound 3, half-maximal inhibitory concentration: 1660 nM
Estimate against measurement, compound 3: 1.5-fold (0.18 log units) above; measured number inside the range.
By their numbers in this assay, from the lowest: compounds 1, 3 and 2 (each within the scatter of the next, the first and the last beyond it).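

In this assay the nitro group, on the aromatic carbon para to a large group, lands within the scatter of both earlier substituents, as a 1.8-fold lower number from compound 2 to compound 3 (0.26 log units; within the scatter) and a 1.5-fold higher number from compound 1 to compound 3 (0.17 log units; within the scatter) show. It therefore sorts with neither fluoro nor methoxy, and the only separation beyond the scatter among the three compounds remains the one between those two, a 2.7-fold higher number from compound 1 to compound 2 (0.43 log units; beyond the scatter), which now looks less like a trend across substituents than a gap bridged by nitro. No accompanying measurement bears on these numbers.

On these data alone, whether the position stays this tolerant with an amine, a carboxylic acid or a bare hydrogen on the ring remains open. Also open, as far as these compounds go, is whether the same substituent changes would read alike on a different version of the shared core.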